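Thiophen-2-yl in Place of Cyclohexyl on a Carbonyl Carbon

A few compounds are considered here, and "the series" means these few. Any claim that something is new, unique, unknown or untested is made for them only; others in the source may bear on it.

Of the compounds shown here, two with a shared core have been measured in an ADME assay on cells (Hepatocyte, Homo sapiens) for metabolic stability; a higher number here means that the compound lasts longer, a lower number that the compound disappears faster. In this test, compound 1 (`Cc1ccc(C(=O)OC2CCC(CN3CCN(c4cc(=O)c5cc(C(F)(F)F)cc([N+](=O)[O-])c5s4)CC3)CC2)cc1`) gives 0.148 h and compound 2 (`O=C(OC1CCC(CN2CCN(c3cc(=O)c4cc(C(F)(F)F)cc([N+](=O)[O-])c4s3)CC2)CC1)C1CCCCC1`) gives 0.0967 h. These two numbers lie within the scatter of each other, so neither compound can be placed clearly ahead of the other.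

Compound 3 (`O=C(OC1CCC(CN2CCN(c3cc(=O)c4cc(C(F)(F)F)cc([N+](=O)[O-])c4s3)CC2)CC1)c1cccs1`) differs from compound 2 at one place, with thiophen-2-yl in place of cyclohexyl on a carbonyl carbon.

Among the measured compounds shown here, only one measured step bears on this change. It is a 1.5-fold lower number from compound 1 to compound 2 (0.18 log units; within the scatter), made at the same carbonyl carbon when cyclohexyl replaced 4-methylphenyl. That single exchange did not move the number beyond the scatter. For the measured compounds named here, no compound carrying thiophen-2-yl has been measured yet, so this evidence is thin. Resting on a 1.5-fold lower number from compound 1 to compound 2 (0.18 log units; within the scatter), no step beyond the scatter is expected in this assay, and no direction can be firmly called.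

The estimated change is a 1.2-fold higher number from compound 2 to compound 3 (0.09 log units; within the scatter). For compound 3 the estimated half-life is 0.12 h, with an expected range from 0.06 h to 0.25 h.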

Compound 3, half-life: 0.0917 h
Compound 3: middle estimate off by 1.3-fold (0.12 log units), on the high side; the range from low to high includes it.
By their numbers in this assay, from the lowest: compounds 3, 2 and 1 (each within the scatter of the next).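

In this assay, thiophen-2-yl on the carbonyl carbon gives a 1.1-fold lower number from compound 2 to compound 3 (0.02 log units; within the scatter) when it replaces cyclohexyl, and a 1.6-fold lower number from compound 1 to compound 3 (0.21 log units; within the scatter) when it replaces 4-methylphenyl. A five-membered aromatic ring with a sulfur atom has now joined a six-membered ring of carbon only and 4-methylphenyl at this place, and all three compounds lie within the scatter of one another, so none of these rings sets its compound apart in this test. No measurement at hand explains these numbers.

Going by these compounds, all three groups are rings attached directly to the carbonyl carbon, so it remains open whether an open-chain group, such as a longer alkyl chain, or a ring carrying an amine or a carboxylic acid, would move the number beyond the scatter. It is also open whether a nitrogen in place of the oxygen on this carbonyl carbon, or a change elsewhere in the shared core, would matter more than the choice among these rings.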